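The compounds below may be only part of what the source reports. "The series", "measured", "known", "first", "only" and "open" are said of these compounds alone.

Measured in a functional assay on A2780 cells (Homo sapiens) for inhibition, read by sulforhodamine B assay, with a stated time of 3 days; a lower number here means a stronger inhibitor, a higher number a weaker inhibitor:
Compound 1 `O=C1Nc2ccc(F)cc2/C1=C\C(=O)c1cccs1`: 2750 nM
Compound 2 `COc1ccc(C(=O)Nc2ccc3c(c2)/C(=C/Nc2cccc(N4CCN(C)CC4)c2)C(=O)N3)cc1`: 2050 nM

Compound 2, at 2050 nM, lies within the usual scatter of compound 1, at 2750 nM, so these two numbers cannot be told apart. The two structures also differ in more than one place, so they form no clean comparison.

Compound 3 `CN1CCN(c2cccc(N/C=C3\C(=O)Nc4ccc(NC(=O)c5c(F)cccc5F)cc43)c2)CC1` has not yet been measured. It matches compound 2 except at one place: 2,6-difluorophenyl in place of 4-methoxyphenyl on a carbonyl carbon. Put simply, 2,6-difluorophenyl stands in place of 4-methoxyphenyl on a carbonyl carbon, and the rest of the molecule stays the same.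

For the measured compounds named here, no measured pair shows what this swap does in this assay, so the data give no direction for it. The best available guide is compound 2 at 2050 nM, and no step beyond the scatter is expected. The expected change is a 1.4-fold lower number from compound 2 to compound 3 (0.14 log units; within the scatter). For compound 3 the estimated value is 1500 nM, with an expected range from 400 nM to 5000 nM.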

Compound 3, half-maximal inhibitory concentration: 2030 nM
Beside the measured number, compound 3's estimate is 1.4-fold (0.13 log units) below it; measured number inside the range.
By their numbers in this assay, from the lowest: compounds 3, 2 and 1 (each within the scatter of the next).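

In this assay, for the compounds shown here, this is the first comparison in which only one place changes, and it shows a 1.0-fold lower number from compound 2 to compound 3 (0.00 log units; within the scatter) when 2,6-difluorophenyl stands in place of 4-methoxyphenyl on a carbonyl carbon. At this position, then, the two aromatic groups cannot be told apart, even though the hydrogen-bond acceptor of 4-methoxyphenyl is absent from 2,6-difluorophenyl and fluorine replaces the oxygen-bearing group. This is a single swap, and nothing measured here explains why the two groups give matching numbers.

The compounds shown leave open whether any change at this position can move the number beyond the scatter, since both groups tested are substituted phenyl rings of the same heavy-atom size. A plain phenyl, a pyridine ring, a small alkyl chain such as methyl or a chain ending in a dimethylamine would show whether this place responds to anything at all, or whether the number depends on other parts of the molecule.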